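This account rests on a few compounds, and the source may have more. Where it says the series, first, only, none or still open, it means among the compounds named here.

In a functional assay on HT-29 cells (Homo sapiens) for antiproliferative activity, read by MTT assay, with a stated time of 48 h (a lower number here means a stronger inhibitor of growth, a higher number a weaker inhibitor of growth), compound 1 `S=C(Nc1ccccc1)N1N=C(c2ccccc2)CC1c1ccc2c(c1)OCCO2` gives 6630 nM. For compound 2 `S=C(Nc1ccccc1)N1N=C(c2ccccc2Br)CC1c1ccc2c(c1)OCCO2` this assay reports only a limit, > 200000 nM. Compound 2 thus sits at the weak end of the two values shown, at the limit of > 200000 nM in this assay, at which 1 of the 2 values shown sits. Going by the values given here, the only measured step is an at least 30-fold higher number from compound 1 to compound 2 (1.47 log units; beyond the scatter). Compound 3 `Cc1ccc(C2=NN(C(=S)Nc3ccccc3)C(c3ccc4c(c3)OCCO4)C2)cc1C` differs from compound 2 by 3,4-dimethylphenyl in place of 2-bromophenyl on a carbon with a double bond to nitrogen. That change takes away the bromo that separates compound 2 from compound 1, while adding methyls present in neither; a gain of the order of an at least 30-fold higher number from compound 1 to compound 2 (1.47 log units; beyond the scatter) is expected, but the methyls leave it uncertain. Compound 3 is therefore estimated at 8000 nM in this assay, with a range from 2000 nM to 100000 nM. That estimate means a step of an at least 25-fold lower number from compound 2 to compound 3 (1.39 log units; beyond the scatter).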

Compound 3, concentration for 50% growth inhibition: 133000 nM
Beside the measured number, compound 3's estimate is 17-fold (1.22 log units) below it; measured number above the stated range.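

In this assay, the large loss is not tied to the bromo: on a carbon with a double bond to nitrogen, 3,4-dimethylphenyl in place of phenyl gives a 20-fold higher number from compound 1 to compound 3 (1.30 log units; beyond the scatter). Against the brominated analogue, the change gives only an at least 1.5-fold lower number from compound 2 to compound 3 (0.17 log units; that floor lies within the scatter), so no order between 3,4-dimethylphenyl and 2-bromophenyl can be stated. Compound 2 remains a limit: the limit of > 200000 nM in this assay, at which 1 of the 3 values shown sits.

From the compounds shown here alone, whether a single methyl at either ring carbon carrying a methyl in compound 3 is enough for the loss remains open. So does whether a methoxy or an amino group on this phenyl keeps the activity of compound 1.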